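Compound 3 to compound 4: a sulfonyl aryl swap

A few compounds are considered here, and "the series" means these few. Any claim that something is new, unique, unknown or untested is made for them only; others in the source may bear on it.

In a functional assay on HEK293 cells (Homo sapiens) for cytotoxicity (a higher number here means that more compound is tolerated, a lower number that less compound is tolerated), compound 1 (`COc1ccc([C@H]2CC(=O)N(c3cccc(N(C)C)c3)C2)cc1OC1CCCC1`) gives > 10000 nM, which is a limit and not a number. Compound 2 (`COc1ccc([C@H]2CC(=O)N(c3cccc(S(C)(=O)=O)c3)C2)cc1OC1CCCC1`) gives > 10000 nM, again a limit. Compound 3 (`COc1ccc(S(=O)(=O)Nc2cccc(N3C[C@@H](c4ccc(OC)c(OC5CCCC5)c4)CC3=O)c2)cc1`) gives > 10000 nM, also a limit, so its position offers only a bound and no exact value.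

Compound 4 (`COc1ccc(OC)c(S(=O)(=O)Nc2cccc(N3C[C@@H](c4ccc(OC)c(OC5CCCC5)c4)CC3=O)c2)c1`) differs from compound 3 by 2,5-dimethoxyphenyl in place of 4-methoxyphenyl on a sulfonyl sulfur. Within the data shown here, no measured step covers this exact change. The nearest are a step that the two limits leave unreadable from compound 1 to compound 3 and a step that the two limits leave unreadable from compound 2 to compound 3, which alter the same aromatic position, while a step that the two limits leave unreadable from compound 1 to compound 2 adds the remaining comparison. None has a readable size. The evidence for this assay is the limit of > 10000 nM in this assay, at which 3 of the 3 values shown sit.

On that basis, no shift beyond the scatter is expected, in either direction, and the expected step is a step that the limit leaves unreadable from compound 3 to compound 4. Another report as a limit is likely. For compound 4 the estimate is 15000 nM, with an expected range of 7000 nM to 30000 nM.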

Compound 4, half-maximal cytotoxic concentration: 7590 nM
Estimate against measurement, compound 4: 2.0-fold (0.30 log units) above; the measured number falls inside the stated range.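

In this assay, among these compounds, compound 4 gives 7590 nM, the first actual number, so the aryl group on the sulfonyl sulfur is a position where a value can be read. Placing 2,5-dimethoxyphenyl there in place of 4-methoxyphenyl gives an at least 1.3-fold lower number from compound 3 to compound 4 (0.11 log units; that floor lies within the scatter), so this floor alone does not establish a real change in tolerance. Among the compounds shown here, the steps among compound 1, compound 2 and compound 3 cannot be read, so this is the only step with a readable size.

From the compounds shown here alone, the true size of the step remains open, as does how much of it belongs to either methoxy group of the 2,5-dimethoxyphenyl. Also open, going by these compounds, is how a carboxylic acid or an amine on that aromatic ring would move the number in this assay.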